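Branching the nitrogen substituent: from benzyl to phenylbutyl

The source may report more compounds than this note shows. Statements on the series, on what has been measured and on what is new or still open speak of the compounds shown alone.

Measured compounds in an assay on Prostate gland for inhibition of steroid 5-alpha-reductase (Rattus norvegicus); a higher number here means a weaker inhibitor, a lower number a stronger inhibitor:
compound 1 `CCCCCCn1ccc2cc(/C(C)=C/C(=O)Nc3ccccc3OCCCC(=O)O)ccc21` gives 77 nM
compound 2 `C/C(=C\C(=O)Nc1ccccc1OCCCC(=O)O)c1ccc2c(ccn2Cc2ccc(C)cc2)c1` gives 88 nM
compound 3 `C/C(=C\C(=O)Nc1ccccc1OCCCC(=O)O)c1ccc2c(ccn2Cc2ccc(C(C)(C)C)cc2)c1` gives 170 nM

Compound 3 holds the highest of the three numbers. One step is a 2.2-fold higher number from compound 1 to compound 3 (0.34 log units; beyond the scatter), while the other pair shows a 1.9-fold higher number from compound 2 to compound 3 (0.29 log units; within the scatter). Compound 1 and compound 2 themselves differ by a 1.1-fold higher number from compound 1 to compound 2 (0.06 log units; within the scatter).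

Compound 4 `CCCC(c1ccccc1)n1ccc2cc(/C(C)=C/C(=O)Nc3ccccc3OCCCC(=O)O)ccc21` has not yet been measured. It arises from compound 3 by 1-phenylbutyl in place of 4-(tert-butyl)benzyl on an aromatic nitrogen. The group that enters carries a phenyl ring, as in compounds 2 and 3, and a short carbon chain on the carbon bound to the nitrogen, as in compound 1. Both of those earlier variations gave numbers close to one another, with compound 3 the only one set apart, and only modestly so. The change from compound 3 to compound 4 is therefore expected to bring the number back toward the region of compounds 1 and 2, a step of a 1.7-fold lower number from compound 3 to compound 4 (0.23 log units; within the scatter) in this assay. Compound 4 is estimated at 100 nM, within a range of 40 nM to 250 nM.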

Compound 4, half-maximal inhibitory concentration: 9.1 nM
Estimate against measurement, compound 4: 11-fold (1.04 log units) above; the measured number lies below the stated range.
By their numbers in this assay, from the lowest: compound 4; then compounds 1, 2 and 3 (each within the scatter of the next, the first and the last beyond it).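

In this assay, 1-phenylbutyl on the aromatic nitrogen gives a 19-fold lower number from compound 3 to compound 4 (1.27 log units; beyond the scatter) and also a 9.7-fold lower number from compound 2 to compound 4 (0.99 log units; beyond the scatter) and an 8.5-fold lower number from compound 1 to compound 4 (0.93 log units; beyond the scatter). Hexyl, 4-methylbenzyl and 4-(tert-butyl)benzyl had given numbers in a narrow span, so this position had seemed to respond little to the group placed on it, yet compound 4 shows that it can respond strongly when one carbon bound to the nitrogen carries both a phenyl ring and a carbon chain. No information is available here to explain this gain.

As far as these compounds go, it remains open whether the gain depends on the ring and chain sharing that carbon or on the length of the chain. An unbranched 4-phenylbutyl group and a shorter 1-phenylethyl group at this nitrogen would separate those two possibilities.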